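Replacing 6-methoxypyridin-3-yl with thiophen-3-yl

A few compounds are considered here, and "the series" means these few. Any claim that something is new, unique, unknown or untested is made for them only; others in the source may bear on it.

Compound 1 `COc1ccc(C(=O)/C=C/c2ccc(N(C)C)cc2)c2c1C=CC(C)(C)O2`: 2750 nM
Compound 2 `COc1ccc(/C=C/C(=O)c2ccc(OC)c3c2OC(C)(C)C=C3)cn1`: > 10000 nM

In a functional assay on SK-OV-3 cells (Homo sapiens) for antiproliferative activity, read by MTT assay, with a stated time of 24 h (on this read-out lower numbers stand for stronger inhibition and higher numbers for weaker inhibition), compound 2 gives > 10000 nM, which is a limit and not a number. Within the data shown here, the one measured step bearing on this position is an at least 3.6-fold higher number from compound 1 to compound 2 (0.56 log units; beyond the scatter). Compound 3 `COc1ccc(C(=O)/C=C/c2ccsc2)c2c1C=CC(C)(C)O2` carries thiophen-3-yl in place of 6-methoxypyridin-3-yl on a double-bonded chain carbon bound to a double-bonded chain carbon. Among the measured compounds shown here, compound 1, at 2750 nM, offers the only actual number, so a move to a lower number is expected, though its size is uncertain. The expected change is an at least 2.2-fold lower number from compound 2 to compound 3 (0.34 log units; beyond the scatter) in this assay. Compound 3 is estimated at 4500 nM, with an expected range of 1500 nM to 14000 nM.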

Compound 3, half-maximal inhibitory concentration: > 10000 nM
Compound 3 ended at the assay's limit; the forecaster's own chance of this, stated with the estimate: 30%; at least 2.2-fold (0.34 log units) between middle value and limit.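

Thiophen-3-yl, like 6-methoxypyridin-3-yl, stays short of the 4-(dimethylamino)phenyl of compound 1 in this assay, with an at least 3.6-fold higher number from compound 1 to compound 3 (0.56 log units; beyond the scatter). Among these compounds, a five-membered aromatic ring at this place therefore fares no better in this comparison than compound 1's six-membered ring, and compound 1 keeps the only actual number. The step between compound 2 and compound 3 cannot be read, and both of their values are limits: the limit of > 10000 nM in this assay, at which 2 of the 3 values shown sit.

On these data alone, how far either compound lies past that limit stays open. Also open, as far as these compounds go, is whether a phenyl ring bearing a plain amine or a methoxy group would match compound 1.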